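This account rests on a few compounds, and the source may have more. Where it says the series, first, only, none or still open, it means among the compounds named here.

The measured compounds:

Compound 1, `COc1cccc(/C=C/C[C@@H]2C[C@@H]([C@@H](O)c3ccc(OC)c(OC)c3)CO[C@H]2c2ccc(OC)c(OC)c2)c1`, gives 16400 nM in a functional assay on HeLa cells (Homo sapiens) for cytotoxicity, read by WST assay, with a stated time of 48 h; a lower number here means a stronger inhibitor, a higher number a weaker inhibitor.
Compound 2, `Cc1ccc(/C=C/C[C@H]2C[C@@H]([C@@H](O)c3ccccc3)CO[C@@H]2c2ccccc2)cc1C`, gives 10000 nM in this assay.
Compound 3, `COc1ccc(/C=C/C[C@@H]2C[C@@H]([C@@H](O)c3ccc(OC)c(OC)c3)CO[C@H]2c2ccccc2)cc1OC`, gives 16100 nM in this assay.

All three compounds share a core and differ in the groups carried on the chain and on the ring positions, and all three sit in the same narrow band of weak inhibition. On the numbers shown, compound 2 holds the lowest figure of the three, but neither compound 3 nor compound 1 is separated from it beyond the scatter, so no order among the three can be claimed and none of them can be called the strongest.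

Compound 4, `COc1cccc(/C=C/C[C@H]2C[C@@H]([C@@H](O)c3ccccc3)CO[C@@H]2c2ccccc2)c1`, has not yet been measured in this assay. It differs from compound 2 in one place: 3-methoxyphenyl in place of 3,4-dimethylphenyl on a double-bonded chain carbon bound to a double-bonded chain carbon. For the measured compounds named here, no pair of measured compounds differing in a single place is available to show what such a change does here, so the expectation rests only on the closeness of the three measured values.

Given that compound 1, compound 2 and compound 3 all lie within the scatter of one another, the step of a 1.2-fold higher number from compound 2 to compound 4 (0.08 log units; within the scatter) is expected to be none beyond the scatter. Compound 4 is therefore estimated at 12000 nM, with a range from 5000 nM to 30000 nM.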

Compound 4, half-maximal inhibitory concentration: 10900 nM
Estimate against measurement, compound 4: 1.1-fold (0.04 log units) above; measured number inside the range.
By their numbers in this assay, from the lowest: compounds 2, 4, 3 and 1 (each within the scatter of the next).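

For the compounds shown here, the step is the first comparison between two compounds that differ in one place: in this assay, 3-methoxyphenyl in place of 3,4-dimethylphenyl on a double-bonded chain carbon bound to a double-bonded chain carbon gives a 1.1-fold higher number from compound 2 to compound 4 (0.04 log units; within the scatter). The entering group brings an oxygen and a hydrogen-bond acceptor that the leaving group lacks, yet this exchange produces no difference that can be told from the scatter, so for this one pair, the assay does not separate the two aryl groups at this place. No supporting measurement is available to explain this result, and the pair itself offers no account of it.

The compounds shown leave open whether any group at this place can move the number beyond the scatter, for example a phenyl ring carrying an amine or a carboxylic acid, or a longer chain in place of the ethenyl link. They also leave open whether the same exchange would give a similar result with the methoxy-bearing groups found elsewhere on compound 1 and compound 3.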